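Lengthening the Amine Chain on a Dopamine Transporter Series

A few compounds are considered here, and "the series" means these few. Any claim that something is new, unique, unknown or untested is made for them only; others in the source may bear on it.

Measured compounds:
Compound 1, `CCNCCC(=O)Nc1cccc2c1CN(C)CC2c1ccccc1`, 190 mg/kg
Compound 2, `CCCCNCCC(=O)Nc1cccc2c1CN(C)CC2c1ccccc1`, > 60 mg/kg
Compound 3, `CCNCC(=O)Nc1cccc2c1CN(C)CC2c1ccc(Cl)cc1`, about 25 mg/kg

All three were tested in a functional assay on the whole organism for inhibition of sodium-dependent dopamine transporter (Mus musculus); on this read-out higher numbers stand for an effect only at larger amounts of compound and lower numbers for an effect already at smaller amounts. Compound 1 gives 190 mg/kg. Compound 2 gives only a limit of this assay, > 60 mg/kg, and not a number. Compound 3 gives about 25 mg/kg, the lowest number of the two that were read; compared with compound 1 it sits far enough away to lie beyond the scatter. How the core of compound 3 differs from the core of compound 1 is not broken down here.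

Compound 2 differs from compound 1 by ethyl in place of hydrogen on a saturated chain carbon, two bonds along the chain from an amine nitrogen. The step this made is a step that the limit leaves unreadable from compound 1 to compound 2; it cannot be read because of the limit of > 60 mg/kg in this assay, at which 1 of the 3 values shown sits.

Compound 4, `CCCCNCC(=O)Nc1cccc2c1CN(C)CC2c1ccc(Cl)cc1`, is not yet measured. Within the data shown here, it differs from compound 3 by ethyl in place of hydrogen on a saturated chain carbon, two bonds along the chain from an amine nitrogen, the same change at the same place as the one made from compound 1 to compound 2. Since the earlier step is unreadable, no measured size can guide the expectation for this assay; the only fact is that the earlier product reached a limit. On that thin basis, compound 4 is expected to show a step of about a 1.6-fold higher number from compound 3 to compound 4 (0.20 log units; within the scatter), with wide uncertainty. Compound 4 is thus estimated at 40 mg/kg, expected to fall between 15 mg/kg and 120 mg/kg.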

Compound 4, dose for half-maximal effect: 22 mg/kg
Compound 4: the middle estimate sits 1.8-fold (0.26 log units) above what was measured; measured number inside the range.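

In this assay, putting ethyl in place of hydrogen on a saturated chain carbon, two bonds along the chain from an amine nitrogen, turns the ethylamino group of compound 3 into the butylamino group of compound 4 and gives a 1.1-fold lower number from compound 3 to compound 4 (0.06 log units; within the scatter), so on this core the longer chain leaves the dose for half-maximal effect unchanged within the usual scatter. The same change on the core of compound 1 leads to compound 2, and compound 2 gives only a limit, > 60 mg/kg, and not a number. The step on that core therefore cannot be read, so the two steps cannot be set side by side, and the data show neither that the change carries over from one core to the other nor that it fails to: the limit of > 60 mg/kg in this assay, at which 1 of the 4 values shown sits.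

With a single readable step, no general rule for this change in the series can be drawn from these compounds. Still open, going by these compounds, is how the read-out would respond to propylamino, to a chain longer than butylamino, or to a carboxylic acid in place of the amine, on either core.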